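Chain Length at the Para Carbon: Predicting a Butyl Analogue

The source may report more compounds than this note shows. Statements on the series, on what has been measured and on what is new or still open speak of the compounds shown alone.

Measured compounds:
Compound 1 `CCCCCCCCCCCCCc1ccc(NC(=O)Nc2c(C(C)C)cccc2C(C)C)cc1` — 11 nM
Compound 2 `CC(C)c1cccc(C(C)C)c1NC(=O)Nc1ccccc1` — 910 nM
Compound 3 `CCCCCCc1ccc(NC(=O)Nc2c(C(C)C)cccc2C(C)C)cc1` — 26 nM

Three ureas built on a shared core have been tested in an assay on isolated protein for inhibition of acyl-CoA:cholesterol acyltransferase (Oryctolagus cuniculus); a higher number here means a weaker inhibitor, a lower number a stronger inhibitor. Compound 2 gives 910 nM and stands highest of the three numbers; its nearest neighbour is compound 3, and the gap is a 35-fold lower number from compound 2 to compound 3 (1.54 log units; beyond the scatter), while compound 1 lies furthest from it. The two measured steps both concern the chain on the aromatic carbon para to a large group. Attaching hexyl there produces a 35-fold lower number from compound 2 to compound 3 (1.54 log units; beyond the scatter), a large drop. Lengthening that chain further, from hexyl to tridecyl, is seen in reverse as a 2.4-fold higher number from compound 1 to compound 3 (0.37 log units; beyond the scatter), a modest step.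

Compound 4 `CCCCc1ccc(NC(=O)Nc2c(C(C)C)cccc2C(C)C)cc1` has not yet been measured. It differs from compound 2 by butyl in place of hydrogen on an aromatic carbon. Butyl is shorter than the hexyl of compound 3 but far more than the hydrogen of compound 2, so the relevant steps are the large one from compound 2 to compound 3 and the modest one between compound 3 and compound 1. A large drop is expected, smaller than that seen for hexyl: the estimated step is an 11-fold lower number from compound 2 to compound 4 (1.06 log units; beyond the scatter). For compound 4 the expected value in this assay is 80 nM, with a range from 30 nM to 250 nM.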

Compound 4, half-maximal inhibitory concentration: 29 nM
Beside the measured number, compound 4's estimate is 2.8-fold (0.44 log units) above it; measured number below the stated range.
By their numbers in this assay, from the lowest: compound 1; then compounds 3 and 4 (each within the scatter of the next); then compound 2.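

In this assay, the short butyl chain on the aromatic carbon already carries a large drop, a 31-fold lower number from compound 2 to compound 4 (1.50 log units; beyond the scatter), so the earlier gain from hexyl does not depend on a chain of that length. Taking the chain back from hexyl to butyl changes nothing that can be read, with a 1.1-fold higher number from compound 3 to compound 4 (0.05 log units; within the scatter), and compounds 3 and 4 cannot be told apart in this assay. Only the much longer tridecyl chain stands apart from butyl, and then only by a modest step, a 2.6-fold higher number from compound 1 to compound 4 (0.42 log units; beyond the scatter), so among these compounds nearly all of the drop comes with replacing hydrogen by a chain of butyl length or longer, while compound 1 shows that further lengthening still has a small effect.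

Nothing in the data given accounts for this behaviour of the chain. As far as these compounds go, it remains open how a methyl, ethyl or propyl group on this carbon would stand relative to hydrogen and butyl, and whether a branched chain such as tert-butyl, or a chain ending in an amine or a carboxylic acid, would keep the number as low.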